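The source may report more compounds than this note shows. Statements on the series, on what has been measured and on what is new or still open speak of the compounds shown alone.

Among the measured compounds shown here, compound 1 `Cc1ccc2c(c1)/C(=N/NC(=S)N/N=C/c1ccccn1)C(=O)N2` holds the only outright number among the three measured compounds in a functional assay on COS-7 cells (Chlorocebus aethiops) for inhibition, read by MTT assay; a lower number here means a stronger inhibitor, a higher number a weaker inhibitor: in this assay compound 1 gives 2120 nM. Compound 2 `COc1ccc(/C=N/NC(=S)N/N=C2\C(=O)Nc3ccc(C)cc32)c(OC)c1` reaches only a limit of the assay, with > 50000 nM. Compound 3 `O=C1Nc2ccc(Br)cc2/C1=N/NC(=S)N/N=C/c1ccccc1Br` likewise gives only a limit, > 50000 nM. Compound 4 `Cc1ccc2c(c1)/C(=N/NC(=S)N/N=C/c1c(Cl)cccc1Cl)C(=O)N2` has not yet been measured in this assay; it differs from compound 1 in one place (2,6-dichlorophenyl in place of pyridin-2-yl on a carbon with a double bond to nitrogen). For the measured compounds named here, no pair of measured compounds differs in a single place, so the size of the step cannot be read off and must be expected. Because the limit of > 50000 nM in this assay, at which 2 of the 3 values shown sit, is where compound 2 and compound 3 sit, compound 4 is expected to come out weaker, by a step of about a 7.1-fold higher number from compound 1 to compound 4 (0.85 log units; beyond the scatter). Compound 4 is estimated at 15000 nM, within a range from 4000 nM to 50000 nM.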

Compound 4, half-maximal inhibitory concentration: 3870 nM
Compound 4: middle estimate off by 3.9-fold (0.59 log units), on the high side; measured number outside the range, below it.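

Replacing pyridin-2-yl with 2,6-dichlorophenyl in this assay gives a 1.8-fold higher number from compound 1 to compound 4 (0.26 log units; within the scatter). The ring nitrogen of pyridin-2-yl is therefore not needed for a measurable number at this position, and a ring of carbon only can stand there. A ring of carbon only does not by itself bring a compound to the limit, which is reached elsewhere in the series: the limit of > 50000 nM in this assay, at which 2 of the 4 values shown sit.

Steps to compound 2 and compound 3 cannot be read, as their values are limits. On these data alone, whether an amine or a carboxylic acid on the ring, or a longer chain in its place, would keep this level remains open.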